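Swapping Trifluoromethyl for Ethoxy in Compound 2

The compounds below may be only part of what the source reports. "The series", "measured", "known", "first", "only" and "open" are said of these compounds alone.

Compound 2 `COc1cc(-c2nc(C)sc2-c2ccc(C(F)(F)F)cc2)cc(OC)c1OC` gives > 10000 nM in a functional assay on HL-60 cells (Homo sapiens) for antiproliferative activity, read by MTT assay, with a stated time of 72 h (a lower number here means a stronger inhibitor, a higher number a weaker inhibitor), and this is only a limit of the assay, not a number. Compound 1 `CCOc1ccc(-c2sc(N(C)C)nc2-c2cc(OC)c(OC)c(OC)c2)cc1` gives a true reading in this assay, at 303 nM. Compound 3 `CCOc1ccc(-c2sc(C)nc2-c2cc(OC)c(OC)c(OC)c2)cc1` has not been measured yet. It differs from compound 2 in a single place: ethoxy in place of trifluoromethyl on an aromatic carbon.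

Within the data shown here, no pair of measured compounds shows this swap on its own, so the size of the step cannot be read directly from the data. The best clue is that compound 1 also carries an ethoxy group and gives 303 nM, although compound 1 is not a single change away from compound 3. On that basis, a large step toward a lower number, well beyond the usual scatter, is expected in this assay. The expected change is an at least 33-fold lower number from compound 2 to compound 3 (1.52 log units; beyond the scatter). For compound 3 the estimated value is 300 nM, with an expected range from 40 nM to 3000 nM.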

Compound 3, half-maximal inhibitory concentration: 253 nM
For compound 3 the middle estimate is 1.2-fold (0.07 log units) above the measured one; low and high end bracket the measured number.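

In this assay, putting ethoxy where trifluoromethyl stood gives an at least 39-fold lower number from compound 2 to compound 3 (1.59 log units; beyond the scatter), so the group on this aromatic carbon, para to a large group, decides whether compounds of this kind show a true reading at all. The second change, methyl in place of dimethylamino on an aromatic carbon, gives a 1.2-fold lower number from compound 1 to compound 3 (0.08 log units; within the scatter), so with ethoxy kept in place, the reading does not depend on dimethylamino. The full size of the first step cannot be read, because compound 2 gives only a limit of the assay and not a number: the limit of > 10000 nM in this assay, at which 1 of the 3 values shown sits.

The compounds shown leave open whether ethoxy itself is required, or whether a hydroxyl group, an amine or a longer chain such as propoxy on the same aromatic carbon would give a similar reading. They also leave open whether dimethylamino paired with trifluoromethyl would bring a compound back from the limit, or whether the large effect of the ethoxy swap holds with either group on the other aromatic carbon.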